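A few compounds are considered here, and "the series" means these few. Any claim that something is new, unique, unknown or untested is made for them only; others in the source may bear on it.

In a physicochemical assay for solubility, read by HPLC, with a stated time of 20 h, at pH 6 (on this read-out higher numbers stand for higher solubility and lower numbers for lower solubility), the series stands as follows:
- compound 1 `Cc1cc(C(=O)O)cc(C)c1NC(=O)c1cc(-c2cccc(CO)c2)ccc1F` gives 774 ug/mL
- compound 2 `Cc1cc(C(=O)O)cc(C)c1NC(=O)c1nc(-c2cccc(CO)c2)ccc1C(F)(F)F` gives 23 ug/mL

Compound 1 holds the higher of the two numbers, and the gap down to compound 2 lies beyond the scatter. These two compounds differ in more than one place, so their gap says nothing about a single exchange.

The next compound to be read is compound 3 `Cc1ccc(-c2cccc(CO)c2)cc1C(=O)Nc1c(C)cc(C(=O)O)cc1C`. Its change from compound 1 is methyl in place of fluoro on an aromatic carbon and amounts to methyl in place of fluoro on an aromatic carbon, ortho to a large group and para to a 3-(hydroxymethyl)phenyl group. The rest of the structure stays the same.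

Within the data shown here, no measured pair isolates this exchange, so the expectation rests on the structural change alone and carries a wide range. A modest drop in this assay is expected, possibly not much beyond the scatter. The estimated step of a 1.9-fold lower number from compound 1 to compound 3 (0.29 log units; within the scatter) is downward and smaller than the gap between the two measured compounds. Compound 3 is estimated at 400 ug/mL with an expected range of 120 ug/mL to 1000 ug/mL on this read-out.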

Compound 3, solubility: 31 ug/mL
Estimate against measurement, compound 3: 13-fold (1.11 log units) above; the whole stated range lies above it.
By their numbers in this assay, from the lowest: compounds 2 and 3 (each within the scatter of the next); then compound 1.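

In this assay, among these compounds, methyl in place of fluoro on the aromatic carbon ortho to a large group and para to a 3-(hydroxymethyl)phenyl group gives a 25-fold lower number from compound 1 to compound 3 (1.40 log units; beyond the scatter), and this is the only single-place exchange read so far. The position is therefore not indifferent to the exchange: one heavy atom replaces one heavy atom, no ring, hydrogen-bond donor, hydrogen-bond acceptor or net charge enters or leaves, and the read-out still moves well beyond the scatter, which the gap between compound 1 and compound 2 could not show, since those two differ in more than one place. Nothing at hand gives a measured reason for the size of this step.

Where chloro, a methoxy group or an amine would fall at this position, nearer compound 1 or nearer compound 3, stays open. From the compounds shown here alone, the step also rests on a single pair, so it remains open whether the same exchange would give a step of like size with another group, such as an aminomethyl group, in place of the 3-(hydroxymethyl)phenyl group.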